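Removing the trifluoromethyl from the benzyl group

The source may report more compounds than this note shows. Statements on the series, on what has been measured and on what is new or still open speak of the compounds shown alone.

Measured so far:
compound 1 `COc1ccccc1CN1CC=C(CCC(=O)NO)C1=O`: 6030 nM
compound 2 `O=C(CCC1=CCN(Cc2cccc(C(F)(F)F)c2)C1=O)NO`: 220 nM

In a functional assay on MDA-MB-231 cells (Homo sapiens) for antiproliferative activity (on this read-out higher numbers stand for weaker inhibition of growth and lower numbers for stronger inhibition of growth), compound 2 stands at the lowest of the two numbers. Compound 1 gives 6030 nM, and compound 2 gives 220 nM, a gap beyond the scatter. The two differ in the substituent on the benzyl ring and its place, so nothing can be pulled apart here; the gap shows only that the benzyl substitution matters on this read-out.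

Compound 3 `O=C(CCC1=CCN(Cc2ccccc2)C1=O)NO` is the unsubstituted benzyl analogue of compound 2: hydrogen in place of trifluoromethyl on an aromatic carbon. For the measured compounds named here, no measured pair shows this change. With the substituent gone, a move toward the higher numbers is expected for compound 3, of moderate size, a 3.6-fold higher number from compound 2 to compound 3 (0.56 log units; beyond the scatter), though a result within the scatter of compound 2 cannot be excluded. Compound 3 is therefore estimated at 800 nM in this assay, with a range from 200 nM to 3500 nM.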

Compound 3, concentration for 50% growth inhibition: 990 nM
Beside the measured number, compound 3's estimate is 1.2-fold (0.09 log units) below it, within the range that was stated.
By their numbers in this assay, from the lowest: compound 2; then compound 3; then compound 1.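

Taken alone, the trifluoromethyl group counts in this assay: its replacement by hydrogen on the aromatic carbon gives a 4.5-fold higher number from compound 2 to compound 3 (0.65 log units; beyond the scatter). The methoxy group, also replaced by hydrogen on an aromatic carbon, acts the opposite way, with a 6.1-fold lower number from compound 1 to compound 3 (0.78 log units; beyond the scatter), so the unsubstituted benzyl ring of compound 3 falls between the two substituted compounds, and the large gap between compound 1 and compound 2 is split into two steps of opposite sign. Nothing measured here accounts for either step.

Going by these compounds, compound 1 and compound 2 differ in both the group and its place, so it remains open whether their order would hold with methoxy and trifluoromethyl on the same ring carbon. Also open, on these data alone, is how a chlorine, a nitrile or an amine on the benzyl ring would compare with hydrogen.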